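The source may report more compounds than this note shows. Statements on the series, on what has been measured and on what is new or still open speak of the compounds shown alone.

Compound 2 `Cn1c(COc2cccc(C(=O)O)c2)nc2ccc(Oc3cc(Cl)ccn3)cc21` is the lower of the two measured compounds in a physicochemical assay for lipophilicity, read by LC-MS, in phosphate buffer, measured as octanol-water partition, with a stated time of 30 min, at pH 7.4, tested at 200 mM (on this read-out higher numbers stand for higher lipophilicity and lower numbers for lower lipophilicity), where compound 2 gives 1.2; compound 1 `Cc1ccc(Oc2ccc3nc(COc4cccc(C(=O)O)c4)n(C)c3n2)cc1C` stands a full step higher, and in this assay compound 1 gives 2.2, a gap beyond the usual scatter. Compound 3 `Cc1cnc(Oc2ccc3nc(COc4cccc(C(=O)O)c4)n(C)c3c2)c(F)c1` has not been measured. It carries 3-fluoro-5-methylpyridin-2-yl in place of 4-chloropyridin-2-yl on an oxygen on an aromatic ring. For the measured compounds named here, no measured pair shows this change, so only a modest step is expected in this assay, with a direction that is not settled and possibly none beyond the scatter: the step from compound 2 to compound 3 is estimated at a number 0.10 log units higher from compound 2 to compound 3 (within the scatter). For compound 3 the expected value in this assay is 1.3, within 0.8 to 1.8.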

Compound 3, distribution coefficient: 1.1
Compound 3: middle estimate off by 0.20 log units, on the high side; measured number inside the range.
By their numbers in this assay, from the lowest: compounds 3 and 2 (each within the scatter of the next); then compound 1.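

In this assay, 3-fluoro-5-methylpyridin-2-yl in place of 4-chloropyridin-2-yl on an oxygen on an aromatic ring gives a number 0.10 log units lower from compound 2 to compound 3 (within the scatter) as the first step read at this position. This position therefore takes one substituted pyridine for another with no shift beyond the scatter. Nothing measured here accounts for this result.

Still open, going by these compounds, is whether an amine or a longer chain in this place would give a step beyond the scatter. The separate shares of the chlorine, fluorine and methyl also remain unread, as all three change in this one step.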